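A few compounds are considered here, and "the series" means these few. Any claim that something is new, unique, unknown or untested is made for them only; others in the source may bear on it.

Values in a functional assay on LOX IMVI cells (Homo sapiens) for inhibition, read by sulforhodamine B assay, with a stated time of 48 h; on this read-out lower numbers stand for stronger inhibition of growth and higher numbers for weaker inhibition of growth:
- compound 1 `CN1CCCN(CCNc2nccc(-c3c(-c4cccc(O)c4)nc4sccn34)n2)S1(=O)=O`: 28200 nM
- compound 2 `O=S(=O)(NCCCNc1nccc(-c2c(-c3cccc(O)c3)nc3sccn23)n1)c1cccc(F)c1`: 5820 nM

Among the measured compounds shown here, compound 2 holds the lower of the two numbers in this assay, and compound 1 is its only neighbour.

Next in the series is compound 3 `O=S(=O)(NCCNc1nccc(-c2c(-c3cccc(O)c3)nc3sccn23)n1)c1ccc(F)cc1`, not yet measured. Its difference from compound 2 is ((4-fluorophenyl)sulfonyl)amino in place of (((3-fluorophenyl)sulfonyl)amino)methyl on a saturated chain carbon, two bonds along the chain from a nitrogen on an aromatic ring. In words, ((4-fluorophenyl)sulfonyl)amino stands in place of (((3-fluorophenyl)sulfonyl)amino)methyl, on a saturated chain carbon, two bonds along the chain from a nitrogen on an aromatic ring.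

For the measured compounds named here, only one measured step acts at this place: a 4.8-fold lower number from compound 1 to compound 2 (0.69 log units; beyond the scatter). It is modest, and it brought in one six-membered aromatic ring of carbon only where a six-membered non-aromatic ring with 3 hetero atoms had stood. The present change is different in kind, since the leaving and entering groups both carry one six-membered aromatic ring of carbon only. Going by the values given here, no measured pair isolates the change itself, so the step from compound 1 serves only as a loose upper guide to size.

The expected step is a 1.1-fold higher number from compound 2 to compound 3 (0.05 log units; within the scatter), with no clear direction and nothing expected beyond the scatter. The estimate for compound 3 is 6500 nM, with an expected range of 2800 nM to 15000 nM.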

Compound 3, concentration for total growth inhibition: 20000 nM
The estimate for compound 3 lay 3.1-fold (0.49 log units) below the measured number; the measured number lies above the stated range.
By their numbers in this assay, from the lowest: compound 2; then compounds 3 and 1 (each within the scatter of the next).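

In this assay the change at this place gives a clear shift (a 3.4-fold higher number from compound 2 to compound 3 (0.54 log units; beyond the scatter)). Both groups carry one six-membered aromatic ring of carbon only, so the number can move beyond the scatter with that ring kept, although loss of the methyl and the switch from 3-fluorophenyl to 4-fluorophenyl travel together in this step and are not separated. The other new step (a 1.4-fold lower number from compound 1 to compound 3 (0.15 log units; within the scatter)) lies within the scatter, so a carbon-only aromatic ring in place of the six-membered non-aromatic ring with 3 hetero atoms brings no gain by itself, and compound 3 goes against any reading that credits the aromatic ring alone for the lower number of compound 2. No measurement at hand gives a reason for these shifts.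

Whether the methyl or the fluorine placement accounts for the step stays open, and (((4-fluorophenyl)sulfonyl)amino)methyl or ((3-fluorophenyl)sulfonyl)amino at this place would separate the two. Also open, going by these compounds, is how a phenylsulfonyl group without fluorine, a longer chain or a terminal amine would read at this place.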